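The source may hold more compounds than are shown below. What is called first, only, known or untested is meant among the compounds shown, and "the series" means these compounds.

Measured compounds:
- compound 1 `CN(C(=O)NC(=O)c1ccc(F)c(F)c1)c1nc(C(F)(F)F)c(C(=O)N/N=C/c2cccc(C(F)(F)F)c2)s1`: 6.52 ug/mL
- compound 2 `CN(C(=O)NC(=O)c1ccc(F)c(F)c1)c1nc(C(F)(F)F)c(C(=O)N/N=C/c2cc(C(F)(F)F)cc(C(F)(F)F)c2)s1`: 5.47 ug/mL

Two compounds of the series have numbers in a functional assay on A549 cells (Homo sapiens) for inhibition, read by MTT assay, with a stated time of 72 h; a higher number here means a weaker inhibitor, a lower number a stronger inhibitor. Compound 1 gives 6.52 ug/mL in this assay, and compound 2 gives 5.47 ug/mL. Among the compounds with values here, the only step between measured compounds, a 1.2-fold lower number from compound 1 to compound 2 (0.08 log units; within the scatter), comes from trifluoromethyl in place of hydrogen on an aromatic carbon and stays within the scatter, so compound 1 and compound 2 cannot be told apart on these numbers; compound 1 has no other neighbour.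

Compound 3 `CN(C(=O)NC(=O)c1c(F)cccc1F)c1nc(C(F)(F)F)c(C(=O)N/N=C/c2cccc(C(F)(F)F)c2)s1` is not yet measured. It differs from compound 1 by 2,6-difluorophenyl in place of 3,4-difluorophenyl on a carbonyl carbon. Within the data shown here, no measured step touches the (difluorophenyl)carbonyl part of the core; the one step on record concerns a different ring and was itself within the scatter. There is therefore no basis for expecting a step beyond the scatter in this assay, in either direction.

From the compounds shown here alone, the estimate for compound 3 is accordingly set at the value of compound 1, with a widened range because the change is unexplored: compound 3 is expected to give 6.5 ug/mL (range 3 ug/mL to 14 ug/mL), a step of a 1.0-fold lower number from compound 1 to compound 3 (0.00 log units; within the scatter).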

Compound 3, half-maximal inhibitory concentration: 27.6 ug/mL
Estimate against measurement, compound 3: 4.2-fold (0.63 log units) below; the measured number lies above the stated range.
By their numbers in this assay, from the lowest: compounds 2 and 1 (each within the scatter of the next); then compound 3.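

In this assay the (difluorophenyl)carbonyl part of the core does respond to change: with the same atoms joined differently, 2,6-difluorophenyl in place of 3,4-difluorophenyl on a carbonyl carbon gives a 4.2-fold higher number from compound 1 to compound 3 (0.63 log units; beyond the scatter) as the only step shown beyond the scatter. The trifluoromethyl change on the other ring gave a 1.2-fold lower number from compound 1 to compound 2 (0.08 log units; within the scatter) and stayed within the scatter, so among the compounds shown, this carbonyl-bound ring is the one place where a change is readable, and there the arrangement of the two fluorines alone separates compound 1 from compound 3. No measurement here bears on why the arrangement matters.

From the compounds shown here alone, with one change on record at this place, it remains open whether the higher number belongs to 2,6-difluorophenyl specifically or would follow other departures from 3,4-difluorophenyl, such as an unsubstituted phenyl, a single fluorine, or a methoxy group or an amine on the ring. Also open, going by these compounds, is whether the same change would produce a step of similar size on the background of compound 2, which carries the second trifluoromethyl group.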